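Thiophen-2-yl to thiophen-3-yl in compound 3

A few compounds are considered here, and "the series" means these few. Any claim that something is new, unique, unknown or untested is made for them only; others in the source may bear on it.

In a physicochemical assay for lipophilicity (on this read-out lower numbers stand for lower lipophilicity and higher numbers for higher lipophilicity), compound 2 `CN1CCN(c2ccc3nc(-c4cccc(-c5cccs5)c4)c(-c4ccncc4)n3n2)CC1` gives 5, level with compound 1 `CN1CCN(c2ccc3nc(-c4ccc(-c5ccccc5)s4)c(-c4ccncc4)n3n2)CC1`, which gives 5. The next structure, compound 3 `CN1CCN(c2ccc3nc(-c4cccc(-c5ccsc5)c4)c(-c4ccncc4)n3n2)CC1`, has the same atoms as compound 2, joined differently: thiophen-3-yl stands in place of thiophen-2-yl on an aromatic carbon (thiophen-3-yl in place of thiophen-2-yl on an aromatic carbon). The swap takes place on a six-membered aromatic ring of carbon only, meta to a large group.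

Going by the values given here, only one measured step offers any guidance: no change at the digits printed from compound 1 to compound 2 (within the scatter). It put 3-(thiophen-2-yl)phenyl in place of 5-phenylthiophen-2-yl on an aromatic carbon, and it stayed within the scatter. Among the compounds with values here, that is a different exchange from the one considered here, and no measured pair shows thiophen-3-yl replacing thiophen-2-yl directly, so the guidance is indirect. On this limited evidence, no shift beyond the scatter is expected in this assay. The expected change is no change at the digits printed from compound 2 to compound 3 (within the scatter). For compound 3 the estimated value is 5, with an expected range from 4.6 to 5.4.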

Compound 3, partition coefficient: 5
Compound 3: the middle estimate sits on the measured number at the digits printed; low and high end bracket the measured number.
By their numbers in this assay, from the lowest: compounds 1, 2 and 3 (each within the scatter of the next).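

Going by these compounds alone, compounds 2 and 3 give the first direct look at this exchange, where thiophen-3-yl takes the place of thiophen-2-yl on an aromatic carbon of a six-membered aromatic ring of carbon only. In this assay the exchange gives no change at the digits printed from compound 2 to compound 3 (within the scatter) and so leaves the read-out level, even though the same atoms are joined differently. The wider exchange of 5-phenylthiophen-2-yl for 3-(thiophen-3-yl)phenyl gives no change at the digits printed from compound 1 to compound 3 (within the scatter) in the same read-out, which places all three compounds level with one another, and no supporting measurement accompanies this result.

These three compounds cover only aryl groups built from phenyl and thiophene rings, so they leave open how this assay would respond if a carboxylic acid, a primary amine or a longer alkyl chain stood at this place. They also leave open whether the exchange of thiophen-2-yl for thiophen-3-yl would stay as quiet at another position on the core or in a read-out of a different kind.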